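The source may hold more compounds than are shown below. What is called first, only, known or untested is meant among the compounds shown, and "the series" means these compounds.

In a functional assay on PC-3 cells (Homo sapiens) for cytotoxicity, read by MTT assay (a higher number here means a weaker inhibitor, a lower number a stronger inhibitor), compound 1 `COc1ccc2cc([C@H](C)c3nnc(SCc4ccc(Cl)cc4)n3-c3ccc(F)cc3)ccc2c1` stands only at the limit <= 400000 nM and has no exact number. Compound 2 `COc1ccc2cc([C@H](C)c3nnc(SCc4ccc(Cl)cc4)n3-c3ccc(Cl)cc3)ccc2c1` gives a number (5800 nM) in the same read-out. Among the measured compounds shown here, the one measured step is a step that the limit leaves unreadable from compound 1 to compound 2 and it offers no size to carry over. Compound 3 `COc1ccc2cc([C@H](C)c3nnc(SCc4ccc(F)cc4)n3-c3ccc(F)cc3)ccc2c1` differs from compound 1 by fluoro in place of chloro on an aromatic carbon here as 4-chlorobenzyl to 4-fluorobenzyl. No direction can be argued, so the expected step that the limit leaves unreadable from compound 1 to compound 3 is an estimate without support from a sized step. For the measured compounds named here, the only anchor is compound 2 at (5800 nM) with a wide margin. Compound 3 is estimated at 20000 nM (range 4000 nM to 100000 nM).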

Compound 3, half-maximal inhibitory concentration: <= 400000 nM
Compound 3 was reported as a limit; the forecaster's own chance of this, stated with the estimate: 20%; the middle value does not contradict the limit.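

Compound 1 and compound 3 both stand only as limits, so no step between them can be read: the limit of <= 400000 nM in this assay, at which 2 of the 3 values shown sit.

From the compounds shown here alone, what the 4-chlorobenzyl to 4-fluorobenzyl change does to the half-maximal inhibitory concentration remains open.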